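A few compounds are considered here, and "the series" means these few. Any claim that something is new, unique, unknown or untested is made for them only; others in the source may bear on it.

Compound 3 `C=CC(=O)Nc1cccc(NC(=O)CSc2nc(Nc3cccc(C)c3)c3ccccc3n2)c1` gives 12100 nM in a functional assay on NCI-H1975 cells (Homo sapiens) for inhibition, read by MTT assay, with a stated time of 72 h (on this read-out lower numbers stand for stronger inhibition and higher numbers for weaker inhibition), and its value sits within the scatter of both compound 1 `O=C(CSc1nc(Nc2ccccc2)c2ccccc2n1)Nc1ccc(Br)cc1`, which gives 10600 nM, and compound 2 `O=C(CSc1nc(Nc2ccccc2)c2ccccc2n1)Nc1ccc(F)c(Cl)c1`, which gives 9390 nM. Compound 4 `C=CC(=O)Nc1cccc(NC(=O)CSc2nc(Nc3ccc(F)c(Cl)c3)c3ccccc3n2)c1` differs from compound 3 by 3-chloro-4-fluorophenyl in place of 3-methylphenyl on a nitrogen on an aromatic ring. Among the compounds with values here, the one measured step that bears on it, a 1.1-fold lower number from compound 1 to compound 2 (0.05 log units; within the scatter), exchanged one halogenated phenyl for the same 3-chloro-4-fluorophenyl on an amide-type nitrogen, though from a different group and at a different nitrogen. Within the data shown here, with only that step to go on, no shift beyond the scatter is expected, and the step from compound 3 is estimated as a 1.1-fold lower number from compound 3 to compound 4 (0.04 log units; within the scatter). Compound 4 is therefore expected to give about 11000 nM, between 5000 nM and 25000 nM.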

Compound 4, half-maximal inhibitory concentration: > 50000 nM
Compound 4: a limit, no number; the forecaster's own chance of this, stated with the estimate: 10%; at least 4.5-fold (0.65 log units) between middle value and limit.
By their numbers in this assay, from the lowest: compounds 2, 1 and 3 (each within the scatter of the next). At a limit, above all of these: compound 4.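

In this assay, 3-chloro-4-fluorophenyl in place of 3-methylphenyl on this nitrogen gives an at least 4.1-fold higher number from compound 3 to compound 4 (0.61 log units; beyond the scatter), so this position responds to the change of aryl group. The same group entering on the amide-type nitrogen gave only a 1.1-fold lower number from compound 1 to compound 2 (0.05 log units; within the scatter). The figure for compound 4 is a limit of the assay, not a number: the limit of > 50000 nM in this assay, at which 1 of the 4 values shown sits.

Going by these compounds, how far compound 4 lies past that limit stays open. So does whether the chlorine or the fluorine alone carries the shift, and how a 3-aminophenyl or 3-methoxyphenyl group on this nitrogen would read.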